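This account rests on a few compounds, and the source may have more. Where it says the series, first, only, none or still open, it means among the compounds named here.

Of the compounds shown here, three of one shared core have been tested in a functional assay on UO-31 cells (Homo sapiens) for inhibition, read by sulforhodamine B assay, with a stated time of 48 h, tested at 0.1 uM; on this read-out lower numbers stand for a stronger effect and higher numbers for a weaker effect at the one concentration tested. Compound 1, `COc1cc(Cl)cc(-c2nn(-c3cccc(NC(=O)Nc4ccc(Cl)c(C(F)(F)F)c4)c3)cc2-c2ccncc2)c1`, gives 55%. Compound 2, `COc1cc(Cl)cc(-c2nn(-c3cccc(NC(=O)Nc4cc(C(F)(F)F)cc(C(F)(F)F)c4)c3)cc2-c2ccncc2)c1`, gives 75%. Compound 3, `COc1cc(Cl)cc(-c2nn(-c3cccc(NC(=O)Nc4ccc(Cl)c(Cl)c4)c3)cc2-c2ccncc2)c1`, gives 500%. On these numbers compound 3 stands highest of the three, which on this read-out means the weakest effect; compound 2 is the nearest and compound 1 the furthest, and both gaps lie beyond the scatter. Within the data shown here, the one single-point step among the measured compounds is a number 445 percentage points higher from compound 1 to compound 3 (beyond the scatter), a large rise.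

The next compound, compound 4, `COc1cc(Cl)cc(-c2nn(-c3cccc(NC(=O)Nc4cccc(C(F)(F)F)c4)c3)cc2-c2ccncc2)c1`, differs from compound 3 in one place: 3-(trifluoromethyl)phenyl in place of 3,4-dichlorophenyl on an amide-type nitrogen. This change bears directly on the step just named, since it again exchanges chloro for trifluoromethyl on the aromatic carbon of the phenyl ring that hangs on the urea nitrogen, only in the opposite direction, and it brings compound 4 close in shape to compound 1 and compound 2. Because a number 445 percentage points higher from compound 1 to compound 3 (beyond the scatter) was so large when chloro entered, a step of similar size back down is expected when trifluoromethyl returns, placing compound 4 near the numbers of compound 1 and compound 2 in this assay. The expected step is a number 435 percentage points lower from compound 3 to compound 4 (beyond the scatter). Compound 4 is therefore estimated at 65%, with a range from 35% to 120%.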

Compound 4, a percentage reported as activity, at one concentration (the size of the read-out at that concentration, not a potency): 50%
Estimate against measurement, compound 4: 15 percentage points above, within the range that was stated.
By their numbers in this assay, from the lowest: compounds 4 and 1 (each within the scatter of the next); then compound 2; then compound 3.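

In this assay, replacing 3,4-dichlorophenyl with 3-(trifluoromethyl)phenyl on the amide-type nitrogen gives a number 450 percentage points lower from compound 3 to compound 4 (beyond the scatter), so the very high number of compound 3 now stands apart from a second close relative and not only from compound 1. The second group on this ring counts for far less once one trifluoromethyl is present: hydrogen in place of chloro gives a number 5 percentage points lower from compound 1 to compound 4 (within the scatter), and hydrogen in place of trifluoromethyl gives a number 25 percentage points lower from compound 2 to compound 4 (beyond the scatter), a modest step that shows a second trifluoromethyl brings no gain here. Nothing available explains why the ring with two chloro groups behaves so differently.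

A ring with a single chloro group and no trifluoromethyl lies outside the compounds shown, so it remains open whether the high number of compound 3 goes with chloro itself or only with the pair of chloro groups. Also open, from the compounds shown here alone, is whether a methoxy group, a nitrile or a carboxylic acid on this ring would give numbers like those of the trifluoromethyl compounds or like that of compound 3.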